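Triazolothiadiazine series: methoxy for trifluoromethoxy step

The source may hold more compounds than are shown below. What is called first, only, known or untested is meant among the compounds shown, and "the series" means these compounds.

Measured so far:
compound 1, `CC(c1ccc(-c2ccccc2)c(F)c1)c1nnc2n1N=C(c1ccc(OC(F)(F)F)cc1)CS2`: 5400 nM
compound 2, `COc1ccc(C2=Nn3c(nnc3C(C)c3ccc(-c4ccccc4)c(F)c3)SC2)cc1`: 4400 nM
compound 3, `CC(C)Cc1ccc(C(C)c2nnc3n2N=C(c2ccc(OC(F)(F)F)cc2)CS3)cc1`: 3000 nM

All three were run in a functional assay on HCT-116 cells (Homo sapiens) for inhibition, read by sulforhodamine B assay, with a stated time of 72 h; on this read-out lower numbers stand for stronger inhibition and higher numbers for weaker inhibition. Compound 1 carries a trifluoromethoxy group; compound 2 differs from it by methyl in place of trifluoromethyl on an oxygen on an aromatic ring, and the step is a 1.2-fold lower number from compound 1 to compound 2 (0.09 log units; within the scatter). Compound 3 shares the trifluoromethoxy group of compound 1 but differs from it elsewhere; the difference between the two cores is not broken down here. Compound 3 gives the lowest of the three numbers, but its gaps to compound 2 and compound 1 both lie within the scatter, so no order among the three can be claimed.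

Compound 4, `COc1ccc(C2=Nn3c(nnc3C(C)c3ccc(CC(C)C)cc3)SC2)cc1`, has not yet been measured. It differs from compound 3 by methyl in place of trifluoromethyl on an oxygen on an aromatic ring, the same change as from compound 1 to compound 2, at the same place. Because that earlier step was a 1.2-fold lower number from compound 1 to compound 2 (0.09 log units; within the scatter), the expected step for compound 4 is a 1.2-fold lower number from compound 3 to compound 4 (0.06 log units; within the scatter), resting on this single precedent. Compound 4 is estimated at 2600 nM, with a likely range of 1200 nM to 5500 nM.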

Compound 4, half-maximal inhibitory concentration: 4200 nM
Beside the measured number, compound 4's estimate is 1.6-fold (0.21 log units) below it; measured number inside the range.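

In this assay the change from trifluoromethoxy to methoxy gives a 1.4-fold higher number from compound 3 to compound 4 (0.15 log units; within the scatter) and, set beside the earlier step, does not separate the two cores: the same change on two cores in this assay, a 1.2-fold lower number (0.09 log units; within the scatter) from compound 1 to compound 2 and a 1.4-fold higher number (0.15 log units; within the scatter) from compound 3 to compound 4, 1.7-fold (0.24 log units) apart, within the scatter of two such steps.

Among the compounds shown here, on these two pairs, the change carries from the core of compound 1 to the core of compound 3 with no step clear of the scatter, so methoxy and trifluoromethoxy cannot be told apart on this read-out. This does not establish a direction for the change or show that the result would hold on any other core, and two pairs give no rule for the series.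

The compounds shown leave open what a longer chain such as ethyl on that oxygen, or an amine or a carboxylic acid in place of the trifluoromethoxy group, would give in this assay. Going by these compounds, whether any replacement at this place moves the number beyond the scatter also remains open.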